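Inverting One Ring Stereocentre of Compound 2

The source may report more compounds than this note shows. Statements on the series, on what has been measured and on what is new or still open speak of the compounds shown alone.

Measured so far:
Compound 1, `N[C@@H](COP(=O)(O)O[C@@H]1CCCO[C@@H]1COC(=O)CCc1ccccc1OCc1cccc(Oc2ccc(Cl)cc2)c1)C(=O)O`: 16.6%
Compound 2, `N[C@@H](COP(=O)(O)O[C@@H]1CCCO[C@@H]1COC(=O)CCc1ccccc1OCc1cccc(Oc2ccccc2)c1)C(=O)O`: 14.8%

In an assay on HEK293-A cells for agonist activity at probable G-protein coupled receptor 34 (Mus musculus), with a stated time of 1.5 h (a lower number here means a smaller maximal response, a higher number a larger maximal response), compound 2 gives 14.8%, the lowest of the two numbers, with compound 1 at 16.6% as its nearest neighbour; the two sit within the scatter of each other, so neither can be called the larger response. Among the compounds with values here, the only measured step, a number 1.8 percentage points lower from compound 1 to compound 2 (within the scatter), concerns a hydrogen in place of chloro on an aromatic carbon and changed little.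

Compound 3, `N[C@@H](COP(=O)(O)O[C@H]1CCCO[C@@H]1COC(=O)CCc1ccccc1OCc1cccc(Oc2ccccc2)c1)C(=O)O`, is not yet measured. It differs from compound 2 as follows: the two compounds have the same atoms and bonds; at least one stereo element is drawn with a configuration in one of them and without one in the other: 1 of 4 stereo elements differ; a stereocentre at a saturated ring carbon is drawn R in compound 2 and S in compound 3 No measured pair alters a stereocentre, so that step gives no guide to the size or direction of this change, and nothing shown argues for a step beyond the scatter. Compound 3 is therefore expected to lie near compound 2, at an estimated 14% with a range of 4% to 30%. The expected step is a number 0.8 percentage points lower from compound 2 to compound 3 (within the scatter), an estimate with wide uncertainty given the absence of any comparable measured pair.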

Compound 3, largest response reached (Emax), in percent of the reference or control that the assay uses: 9.8%
Estimate against measurement, compound 3: 4.2 percentage points above, and the stated range covers the measured number.
By their numbers in this assay, from the lowest: compounds 3, 2 and 1 (each within the scatter of the next).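

In this assay, within the data shown here, drawing this saturated ring carbon S rather than R gives a number 5 percentage points lower from compound 2 to compound 3 (within the scatter), which is the first measured information on the stereochemistry at this position. The configuration of this one ring carbon therefore does not move the maximal response outside the usual scatter, so this pair gives no sign that the response depends on how the position is drawn, though the pair is a single comparison on a single compound and a small real effect could hide within that scatter. One caution applies to reading this pair as a clean swap of one defined form for the other: the fact that one of compounds 2 and 3 is drawn with a defined configuration and the other without, at the place where they differ

The compounds shown leave open whether inverting any of the other stereo elements would give a step beyond the scatter, and whether chloro in place of hydrogen on the aromatic carbon would behave the same way in the S form as it does in the R form. They also leave open whether a different kind of change, such as an amide in place of the ester, would shift the response by more than the change of configuration does.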